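Working notes: the step from compound 1 to compound 4

The source may hold more compounds than are shown below. What is called first, only, known or untested is meant among the compounds shown, and "the series" means these compounds.

In a functional assay on A549 cells (Homo sapiens) for antiproliferative activity, read by sulforhodamine B assay, with a stated time of 3 days (on this read-out higher numbers stand for weaker inhibition of growth and lower numbers for stronger inhibition of growth), compound 1 (`O=C(Nc1nccs1)c1cccc(Nc2ncc(F)c(Nc3ccc(F)cc3)n2)c1`) gives no number, only a limit: > 10000 nM. Going by the values given here, the series so far is dominated by the limit of > 10000 nM in this assay, at which 2 of the 3 values shown sit. Compound 4 (`O=C(Nc1cccc(Nc2ncc(F)c(Nc3ccc(F)cc3)n2)c1)c1ccccc1`) has benzamido in place of (1,3-thiazol-2-yl)carbamoyl on an aromatic carbon, (benzamido in place of (1,3-thiazol-2-yl)carbamoyl on an aromatic carbon).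

Among the compounds with values here, no measured step starts from compound 1, so the closest guidance comes from two compounds that differ from compound 4 only in the group on the carbonyl carbon. In this assay, compound 2 (`O=C(Nc1cccc(Nc2ncc(F)c(Nc3ccc(F)cc3)n2)c1)c1cccc([N+](=O)[O-])c1`), with 3-nitrophenyl, gives 7250 nM. Compound 3 (`CN(C)c1ccc(C(=O)Nc2cccc(Nc3ncc(F)c(Nc4ccc(F)cc4)n3)c2)cc1`), with 4-(dimethylamino)phenyl, is also a limit, > 10000 nM. Within the data shown here, the single measured step, an at least 1.3-fold higher number from compound 2 to compound 3 (0.13 log units; that floor lies within the scatter), is small and gives no sign that the group on the carbonyl carbon moves this assay much.

Compound 4 therefore seems likely to fall close to compound 2 and compound 3, and a limit result would be no surprise. No change beyond the scatter is expected, though any shift would be towards a lower number, given the limit for compound 1. The expected step is an at least 1.1-fold lower number from compound 1 to compound 4 (0.04 log units; that floor lies within the scatter). The estimate for compound 4 is 9000 nM, with an expected range of 4000 nM to 20000 nM.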

Compound 4, concentration for 50% growth inhibition: 37800 nM
Compound 4: the middle estimate sits 4.2-fold (0.62 log units) below what was measured; the measured number lies above the stated range.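

Going by these compounds alone, replacing nitro with hydrogen gives the first step that clearly lies beyond the scatter: a 5.2-fold higher number from compound 2 to compound 4 (0.72 log units; beyond the scatter). In this assay, the substituent on the phenyl ring of the benzamido group therefore can change the read-out, which the earlier step, an at least 1.3-fold higher number from compound 2 to compound 3 (0.13 log units; that floor lies within the scatter), could not show because its floor lies within the scatter. The steps to compound 4 from compound 1 and from compound 3 cannot be read, because each of those two compounds stands at a limit: the limit of > 10000 nM in this assay, at which 2 of the 4 values shown sit.

Within the data shown here, with only one readable step, the result ties the lower number of compound 2 to the 3-nitrophenyl group alone, and it remains open whether this is specific to nitro or would hold for other groups in the same place on the ring. A 3-aminophenyl, 3-cyanophenyl or 3-carboxyphenyl group in place of 3-nitrophenyl would test this, and a 4-nitrophenyl group would show whether the position of the nitro group on the ring matters as well.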